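Hydroxamate series: methyl to isopropyl on the aryl ring

This account rests on a few compounds, and the source may have more. Where it says the series, first, only, none or still open, it means among the compounds named here.

Measured so far:
compound 1 `Cc1ccc(-c2nc(CNc3ccc(C(=O)NO)cc3)n(-c3ccccc3)n2)cc1`, 62.2%
compound 2 `Cc1ccc(-n2nc(-c3ccccc3)nc2CNc2ccc(C(=O)NO)cc2)cc1C`, 53%

Both compounds were tested in an assay on Sf9 cells for inhibition of protein deacetylase HDAC6 (Homo sapiens), read by fluorescence, with a stated time of 40 min, tested at 100 nM; a lower number here means less inhibition, a higher number more inhibition at the concentration tested (going by the name of the read-out). Compound 1 gives 62.2% and compound 2 gives 53%; the two numbers lie within the usual scatter of each other, so no ranking between them is claimed. Going by the values given here, no step between compounds differing in one place is available.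

Compound 3 `CC(C)c1ccc(-c2nc(CNc3ccc(C(=O)NO)cc3)n(-c3ccccc3)n2)cc1` is not yet measured. Relative to compound 1 it carries one change: isopropyl in place of methyl on an aromatic carbon. Among the compounds with values here, nothing among the measured compounds shows how this kind of exchange plays out in this assay, so the expectation rests on the shared core and on compound 1 alone. The step from compound 1 to compound 3 is expected to be small, a number 2.2 percentage points lower from compound 1 to compound 3 (within the scatter), with no change beyond the scatter in either direction. Compound 3 is therefore estimated at 60%, within a range from 42% to 78%.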

Compound 3, a percentage reported as inhibition, at one concentration (the size of the read-out at that concentration, not a potency): 27.6%
Compound 3: middle estimate off by 32.4 percentage points, on the high side; measured number below the stated range.
By their numbers in this assay, from the lowest: compound 3; then compounds 2 and 1 (each within the scatter of the next).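

Going from 4-methylphenyl to 4-isopropylphenyl in this assay gives a number 34.6 percentage points lower from compound 1 to compound 3 (beyond the scatter), the first step in the series that differs in one place. The group on this aromatic carbon, para to a large group, therefore matters to the read-out, and a change confined to this one alkyl group is enough to move the number beyond the scatter while the shared core stays the same. The data at hand offer nothing that bears on why the number moves in this way.

From the compounds shown here alone, with only methyl and isopropyl at this position, the shape of the trend remains open, including whether ethyl, tert-butyl or methoxy in the same place would stay close to compound 1 or fall with compound 3. Equally open, going by these compounds, is whether the same exchange would have a step of similar size on the aryl arrangement of compound 2.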